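This account rests on a few compounds, and the source may have more. Where it says the series, first, only, none or still open, it means among the compounds named here.

In a functional assay on the whole organism with Rattus norvegicus as the target (a lower number here means that less compound is needed, a higher number that more compound is needed for the effect), compound 1 `O=C(O)c1cc(-c2ccc(F)cc2)ccc1O` gives 14 mg/kg. Compound 2 `O=C(O)c1cc(-c2ccc(Cl)cc2)ccc1O` gives 24 mg/kg, and a 1.7-fold higher number from compound 1 to compound 2 (0.23 log units; within the scatter) shows that these two values cannot be told apart. Compound 3 `O=C(O)c1cc(-c2ccc(I)cc2)ccc1O` gives 120 mg/kg, the highest number of the three, so compound 1 shares the low end of this short series with compound 2.

Compound 4 `Cc1cc(-c2ccc(F)cc2)cc(C(=O)O)c1O` has not yet been measured. It keeps the fluoro group of compound 1 and adds one change: methyl in place of hydrogen on an aromatic carbon. The new methyl sits ortho to the hydroxy group and meta to the carboxy group.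

Among the compounds with values here, no measured step changes anything at that place, so the evidence is only indirect. All three known steps swap one halogen for another on an aromatic carbon. Besides the step already given, they are an 8.6-fold higher number from compound 1 to compound 3 (0.93 log units; beyond the scatter) and a 5.0-fold higher number from compound 2 to compound 3 (0.70 log units; beyond the scatter). The larger steps both involve iodo, a change that compound 4 does not make. Within the data shown here, the only step without iodo is the one to compound 2, and it stays within the scatter. A step beyond the scatter is therefore not expected here, though the uncertainty is wide. The expected result is a 1.4-fold higher number from compound 1 to compound 4 (0.15 log units; within the scatter). For compound 4 the estimated value is 20 mg/kg, with an expected range from 7 mg/kg to 60 mg/kg.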

Compound 4, dose for half-maximal effect: 60 mg/kg
Estimate against measurement, compound 4: 3.0-fold (0.48 log units) below; low and high end bracket the measured number.
By their numbers in this assay, from the lowest: compounds 1 and 2 (each within the scatter of the next); then compounds 4 and 3 (each within the scatter of the next).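

Within the data shown here, every step so far in this assay swapped one halogen for another, so they said nothing about the rest of the core of compound 1. Among these compounds, this result is the first reading from a different place, ortho to a hydroxy group and meta to a carboxy group, and methyl in place of hydrogen there gives a 4.3-fold higher number from compound 1 to compound 4 (0.63 log units; beyond the scatter), so more compound is needed for the effect. The position is therefore not indifferent to change, since even this one added heavy atom moves the number beyond the scatter, but no measurement offered here explains the shift.

On these data alone, whether other groups at this same place, such as ethyl, methoxy or an amine, would raise the number further, leave it unchanged or lower it remains open, and a single step cannot show a trend. Also open, as far as these compounds go, is whether methyl would give a step of similar size with chloro in place of fluoro, as in compound 2, or whether its effect depends on the halogen.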